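Methoxy Added to an Inactive Dichlorophenyl Analogue

This account rests on a few compounds, and the source may have more. Where it says the series, first, only, none or still open, it means among the compounds named here.

Compound 1 `C=CCn1c(=O)/c(=C\c2ccc(Cl)c(Cl)c2)[nH]c(=O)/c1=C\c1ccccc1` is the starting point. In a functional assay on BGC-823 cells (Homo sapiens) for cytotoxicity, read by CCK-8 assay, with a stated time of 72 h (a higher number here means a weaker inhibitor, a lower number a stronger inhibitor), compound 1 is reported only as "not active" (no number reported), so no single number places it. Compound 2 `C=CCn1c(=O)/c(=C\c2cccc(Br)c2)[nH]c(=O)/c1=C\c1ccccc1OC` already carries a methoxy group, and in this assay compound 2 gives 5900 nM. Compound 3 `C=CCn1c(=O)/c(=C\c2ccc(Cl)c(Cl)c2)[nH]c(=O)/c1=C\c1ccccc1OC` keeps the dichlorophenyl portion of compound 1 and adds that group: methoxy in place of hydrogen on an aromatic carbon. For the measured compounds named here, with no measured step between neighbours, the change is expected to move compound 3 toward measurable inhibition in this assay, by an uncertain amount. Compound 3 is therefore estimated at 8000 nM, between 2500 nM and 30000 nM.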

Compound 3, half-maximal inhibitory concentration: "not active" (no number reported)
Compound 3 has no reported number here, so the estimate cannot be set against anything.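

In this assay compound 1 gives "not active" (no number reported) and compound 3 gives "not active" (no number reported), so no step can be read between them. The compounds shown leave open how large any effect of the phenyl to 2-methoxyphenyl change might be. No supporting evidence bears on this result.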